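Trifluoromethyl to hydroxy in a growth inhibition series

The source may report more compounds than this note shows. Statements on the series, on what has been measured and on what is new or still open speak of the compounds shown alone.

In a functional assay on A2780 cells (Homo sapiens) for inhibition, read by sulforhodamine B assay (a higher number here means a weaker inhibitor of growth, a lower number a stronger inhibitor of growth), compound 2 (`Cc1ccc2[nH]c(-c3ccc(-c4ccc(-c5ccc(C(F)(F)F)cc5)cc4)cc3)nc2c1`) gives 12300 nM and compound 1 (`Cc1ccc2[nH]c(-c3ccc(-c4ccc(-c5ccc(F)cc5)cc4)cc3)nc2c1`) gives 24600 nM (within the scatter of each other). Compound 3 (`Cc1ccc2[nH]c(-c3ccc(-c4ccc(-c5ccc(O)cc5)cc4)cc3)nc2c1`) differs from compound 2 by hydroxy in place of trifluoromethyl on an aromatic carbon. Among the compounds with values here, the only measured step on that carbon (a 2.0-fold lower number from compound 1 to compound 2 (0.30 log units; within the scatter)) stayed within the scatter, and no measured step brings in a hydroxy, so the data give no direction. The expected change is a 1.0-fold lower number from compound 2 to compound 3 (0.01 log units; within the scatter) (no expected shift beyond the scatter). For compound 3 the estimated value is 12000 nM (expected range 3500 nM to 40000 nM).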

Compound 3, concentration for 50% growth inhibition: 31200 nM
Estimate against measurement, compound 3: 2.6-fold (0.41 log units) below, within the range that was stated.
By their numbers in this assay, from the lowest: compounds 2, 1 and 3 (each within the scatter of the next, the first and the last beyond it).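

In this assay, this aromatic carbon shows its first step beyond the scatter: hydroxy in place of trifluoromethyl gives a 2.5-fold higher number from compound 2 to compound 3 (0.40 log units; beyond the scatter), a modest move toward weaker growth inhibition. Hydroxy in place of fluoro gives a 1.3-fold higher number from compound 1 to compound 3 (0.10 log units; within the scatter), so the new group separates from trifluoromethyl but not from fluoro. Nothing available explains this difference. The compounds shown leave open how an amine or a carboxylic acid on this carbon would compare with hydroxy and trifluoromethyl. They also leave open whether any group here can shift the number further than this modest step.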